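Trimming a Benzyloxy Group in a Weak Cytotoxic Series

The source may report more compounds than this note shows. Statements on the series, on what has been measured and on what is new or still open speak of the compounds shown alone.

Three acrylic acids have been tested in a functional assay on KB cells (Homo sapiens) for cytotoxicity, read by MTT assay, with a stated time of 72 h; a lower number here means a stronger inhibitor, a higher number a weaker inhibitor. Compound 1 `CC(=O)n1cc(/C=C(/C(=O)O)c2ccccc2)c2cc(OCc3ccccc3)ccc21` gives 55500 nM, compound 2 `COc1ccc(/C(=C\c2c[nH]c3ccc(OCc4ccccc4)cc23)C(=O)O)cc1` gives 38500 nM, and compound 3 `CC(=O)n1cc(/C=C(/C(=O)O)c2ccc(OCc3ccccc3)cc2)c2cc(OCc3ccccc3)ccc21` gives 43000 nM. Compound 3 thus holds the second highest of the three numbers, yet both its neighbours lie within the scatter of it. Compound 4 `COc1ccc(/C(=C\c2cn(C(C)=O)c3ccc(OCc4ccccc4)cc23)C(=O)O)cc1` is compound 3 with hydrogen in place of phenyl on a saturated chain carbon bound to an oxygen on an aromatic ring. Within the data shown here, the only measured step touching this group, a 1.3-fold lower number from compound 1 to compound 3 (0.11 log units; within the scatter), ran the other way, adding the benzyloxy group, and stayed within the scatter. Compound 2, which also carries a methoxy group but differs from compound 3 in two places, shows a number close to compound 3. Compound 4 is therefore expected to move little, a 1.0-fold higher number from compound 3 to compound 4 (0.02 log units; within the scatter), with an estimated 45000 nM and a range from 20000 nM to 100000 nM.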

Compound 4, half-maximal inhibitory concentration: > 100000 nM
Compound 4: a limit, no number; the forecaster's own chance of this, stated with the estimate: 10%; middle value at least 2.2-fold (0.34 log units) away from the limit.
By their numbers in this assay, from the lowest: compounds 2, 3 and 1 (each within the scatter of the next). At a limit, above all of these: compound 4.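

The reading for compound 4 is a limit and not a number: the limit of > 100000 nM in this assay, at which 1 of the 4 values shown sits. Trimming benzyloxy to methoxy at this place is not a neutral change, with an at least 2.3-fold higher number from compound 3 to compound 4 (0.36 log units; beyond the scatter), so the phenyl counts here in a way the earlier compounds could not show. With the methoxy in place, the acetyl on the aromatic nitrogen counts too, with an at least 2.5-fold higher number from compound 2 to compound 4 (0.41 log units; beyond the scatter), while an at least 1.8-fold higher number from compound 1 to compound 4 (0.25 log units; that floor lies within the scatter) settles nothing about methoxy against hydrogen. Going by these compounds, how an ethoxy, a longer chain or a hydroxyl would read at this place stays open.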